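A Second Methoxy Group on an Indole-Type Scaffold

The compounds below may be only part of what the source reports. "The series", "measured", "known", "first", "only" and "open" are said of these compounds alone.

Of the compounds shown here, three have been tested in a functional assay on SR cells (Homo sapiens) for inhibition, read by sulforhodamine B assay, with a stated time of 48 h; a higher number here means a weaker inhibitor of growth, a lower number a stronger inhibitor of growth. Compound 1 `COc1ccc(-c2[nH]c3ccccc3c2/C=C(\C#N)S(=O)(=O)c2ccccc2)cc1` carries a methoxyphenyl group on its core and a nitrile together with a phenylsulfonyl group on the side chain; in this assay compound 1 gives 350 nM. Compound 2 `COc1ccc2[nH]c(-c3ccccc3)c(C=C(C#N)C#N)c2c1` instead bears two nitriles on the side chain and a methoxy group on the fused part of the core, and compound 2 gives 865 nM. Compound 3 `CCOC(=O)C(=Cc1c(-c2ccccc2)[nH]c2ccccc12)C(=O)OCC` has two ethyl ester groups on the side chain, and compound 3 gives 2100 nM. Of the three numbers, compound 1 has the lowest, which here means the strongest growth inhibition, and both other compounds lie beyond the usual scatter from it.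

Compound 4 `COc1ccc(-c2[nH]c3ccc(OC)cc3c2/C=C(\C#N)S(=O)(=O)c2ccccc2)cc1` keeps everything in compound 1 but adds one group: methoxy in place of hydrogen on an aromatic carbon. Going by the values given here, no measured pair shows this exact change, so the size of the step is open. The expectation for the step from compound 1 to compound 4 is a 1.1-fold lower number from compound 1 to compound 4 (0.03 log units; within the scatter), that is, no change beyond the scatter in either direction. Compound 4 is therefore estimated to give 330 nM in this assay, with a plausible range from 120 nM to 900 nM.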

Compound 4, concentration for 50% growth inhibition: 305 nM
Estimate against measurement, compound 4: 1.1-fold (0.03 log units) above, within the range that was stated.
By their numbers in this assay, from the lowest: compounds 4 and 1 (each within the scatter of the next); then compound 2; then compound 3.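

In this assay the swap of hydrogen for methoxy on an aromatic carbon of the fused ring system gives a 1.1-fold lower number from compound 1 to compound 4 (0.06 log units; within the scatter) and so stays within the usual scatter of repeated measurements. Going by these compounds alone, this is the only measured pair here that differs in one place, and it shows that this carbon can carry methoxy while compound 1 and compound 4 cannot be told apart in growth inhibition. No measurement at hand explains this result.

From the compounds shown here alone, whether a longer chain such as butoxy, or an amine or a carboxylic acid, would also stay within the scatter at this carbon remains open. Also open, going by these compounds, is whether the same change would give a similar step with two nitriles or two ethyl esters on the side chain.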